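A Further Hydroxy Added to Compound 3

This account rests on a few compounds, and the source may have more. Where it says the series, first, only, none or still open, it means among the compounds named here.

Three compounds built on one shared core were tested in a functional assay on ANN-1 cells (Mus musculus) for cytotoxicity; a higher number here means a weaker inhibitor, a lower number a stronger inhibitor. Compound 1 `Oc1cc(O)c2nc(-c3ccc(O)c(O)c3)sc2c1` gives 58500 nM, compound 2 `Oc1ccc(-c2nc3cc(O)ccc3s2)cc1` gives 25500 nM, and compound 3 `Oc1ccc(-c2nc3cc(O)c(O)cc3s2)cc1` gives 9000 nM, the lowest number of the three. Compound 4 `Oc1ccc(-c2nc3cc(O)c(O)cc3s2)cc1O` has not yet been tested; it differs from compound 3 by hydroxy in place of hydrogen on an aromatic carbon. For the measured compounds named here, the only measured step that also introduces a hydroxy is a 2.8-fold lower number from compound 2 to compound 3 (0.45 log units; beyond the scatter), where the new group went onto the shared core. Compound 1, which also carries a hydroxy ortho to a hydroxy group but differs from compound 3 in further places, gives the highest number. A modest lowering is therefore expected: a 1.5-fold lower number from compound 3 to compound 4 (0.18 log units; within the scatter). Compound 4 is estimated at 6000 nM, with a range from 2500 nM to 15000 nM.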

Compound 4, half-maximal inhibitory concentration: 32000 nM
The estimate for compound 4 lay 5.3-fold (0.73 log units) below the measured number; the measured number lies above the stated range.
By their numbers in this assay, from the lowest: compound 3; then compounds 2, 4 and 1 (each within the scatter of the next, the first and the last beyond it).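

In this assay the new hydroxy, ortho to a hydroxy group on the ring of carbon only, brings a 3.6-fold higher number from compound 3 to compound 4 (0.55 log units; beyond the scatter) and so gives a weaker inhibitor. The same swap of hydrogen for hydroxy on the shared core brought a 2.8-fold lower number from compound 2 to compound 3 (0.45 log units; beyond the scatter), so across these two steps the direction of the change depends on where the hydroxy stands. Nothing available here explains this reversal. Still open, from the compounds shown here alone, is whether a methoxy or an amine at this position would also raise the number, or whether this rise is specific to hydroxy.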